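Anilide series: hydroxy in place of trifluoromethyl

The source may hold more compounds than are shown below. What is called first, only, known or untested is meant among the compounds shown, and "the series" means these compounds.

Measured compounds:
compound 1, `O=C(Nc1ccccc1O)C1CCc2ccccc2N1C(=O)c1ccccc1Cl`, a functional assay on MDA-MB-231 cells (Homo sapiens) for cytotoxicity, read by sulforhodamine B assay, with a stated time of 72 h; a lower number here means a stronger inhibitor of growth, a higher number a weaker inhibitor of growth: 47400 nM
compound 2, `O=C(Nc1ccc(C(F)(F)F)cc1)C1CCc2ccccc2N1`, this assay: 24200 nM

Compound 2 gives the lower of the two numbers, but the gap to compound 1 is within the scatter, so the two are not separated by the data. The two structures differ in more than one place at once, so no single change can be read from them.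

Compound 3, `O=C(Nc1ccc(O)cc1)C1CCc2ccccc2N1`, differs from compound 2 by hydroxy in place of trifluoromethyl on an aromatic carbon. Within the data shown here, no measured pair isolates this change. A step toward weaker growth inhibition, of a size at or just beyond the scatter, is expected, because the hydroxy-bearing compound 1 gives 47400 nM in this assay and neither measured compound reaches a low number. The expected step is a 1.6-fold higher number from compound 2 to compound 3 (0.20 log units; within the scatter). Compound 3 is estimated at 38000 nM, with a range from 12000 nM to 120000 nM. Given how high both measured numbers sit, a limit instead of a number is a real possibility for compound 3.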

Compound 3, concentration for 50% growth inhibition: > 100000 nM
Compound 3: a limit, no number; the forecaster's own chance of this, stated with the estimate: 25%; middle value at least 2.6-fold (0.42 log units) from the limit.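

Hydroxy in place of trifluoromethyl, on an aromatic carbon para to a large group, is the first change in the series that can be read in one place, and it gives an at least 4.1-fold higher number from compound 2 to compound 3 (0.61 log units; beyond the scatter). The earlier pair differed in more than one place and its values lay within the scatter, so it said nothing about this position; here a single replacement on the anilide ring moves growth inhibition in this assay beyond the scatter, and trifluoromethyl is the better of the two groups at this position. The step is only a lower bound, so its full size stays unknown, and the reading rests on a single compound at the top of the measurable range: the limit of > 100000 nM in this assay, at which 1 of the 3 values shown sits.

This one pair cannot tell whether the difference comes from losing trifluoromethyl or from gaining hydroxy, and a methoxy, a chlorine or an amine on the same aromatic carbon would help to separate the two. Going by these compounds, whether a carbonyl-linked acyl group on the core of compound 2 changes this position's response also stays open, since compound 1 differs from compound 2 in more than one place.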